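The source may report more compounds than this note shows. Statements on the series, on what has been measured and on what is new or still open speak of the compounds shown alone.

Compound 3 `Cc1nc(-c2ccccc2)sc1C(=O)CSc1nc(-c2ccc(Cl)c(Cl)c2)c(C#N)c(=O)[nH]1` gives 24.4% in a functional assay on U-87MG ATCC cells for antiproliferative activity against U-87 MG (Homo sapiens), read by MTT assay, with a stated time of 48 h, tested at 100 uM; on this read-out lower numbers stand for a stronger effect and higher numbers for a weaker effect at the one concentration tested; compound 1 `COc1cccc(-c2nc(SCC(=O)c3sc(-c4ccccc4)nc3C)[nH]c(=O)c2C#N)c1` gives 21.8%; compound 2 `Cc1nc(-c2ccc(Cl)cc2)sc1C(=O)CSc1nc(-c2cccc(Cl)c2)c(C#N)c(=O)[nH]1` gives 12.5%.

Compound 3 shows the highest of the three numbers, with compound 1 within the scatter of it and compound 2 beyond it. Compound 4 `Cc1nc(-c2ccccc2)sc1C(=O)CSc1nc(-c2cccc(Cl)c2)c(C#N)c(=O)[nH]1` differs from compound 3 by hydrogen in place of chloro on an aromatic carbon. Among the measured compounds shown here, no measured step removes a chloro in this way. For the measured compounds named here, the only step joining two measured compounds, a number 2.6 percentage points higher from compound 1 to compound 3 (within the scatter), changes the same ring and stays within the scatter. Compound 2, which carries the 3-chlorophenyl of compound 4 but a second change elsewhere, stands lower than compound 3. Compound 4 is therefore expected to give 18%, between 8% and 30%, the step of a number 6.4 percentage points lower from compound 3 to compound 4 (within the scatter) being estimated as one that may or may not exceed the scatter.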

Compound 4, a percentage reported as activity, at one concentration (the size of the read-out at that concentration, not a potency): 10%
For compound 4 the middle estimate is 8 percentage points above the measured one; low and high end bracket the measured number.
By their numbers in this assay, from the lowest: compounds 4, 2, 1 and 3 (each within the scatter of the next, the first and the last beyond it).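

Going from 3,4-dichlorophenyl to 3-chlorophenyl gives a number 14.4 percentage points lower from compound 3 to compound 4 (beyond the scatter) in this assay, so this ring responds to a single chloro, a sensitivity that the earlier comparison of its substituents did not show. Chloro in place of methoxy on the same ring gives a number 11.8 percentage points lower from compound 1 to compound 4 (beyond the scatter), which again sets the 3-chlorophenyl compound apart. Among the compounds shown here, removing the chloro from the other phenyl group gives a number 2.5 percentage points lower from compound 2 to compound 4 (within the scatter), so the same kind of change elsewhere in the molecule shows no such step.

On these data alone, how an amine or a longer chain on the first ring would read remains open. Nothing available explains these steps.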